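Piperazinylmethyl Substitution on Two Linker Variants of the Series

A few compounds are considered here, and "the series" means these few. Any claim that something is new, unique, unknown or untested is made for them only; others in the source may bear on it.

Compound 1 `O=C(CCSc1ccc2c(/C=C/c3ccccn3)n[nH]c2c1)Nc1cccc(C(F)(F)F)c1` and compound 2 `CN1CCN(Cc2ccc(NC(=O)CCSc3ccc4c(/C=C/c5ccccn5)n[nH]c4c3)cc2C(F)(F)F)CC1` share one core, compound 2 carrying the change ((4-methylpiperazin-1-yl)methyl in place of hydrogen on an aromatic carbon). In an ADME assay on BaF3 cells (Mus musculus) for antiproliferative activity, read by CCK-8 assay, with a stated time of 72 h (a higher number here means a weaker inhibitor of growth, a lower number a stronger inhibitor of growth), compound 1 gives 2300 nM, and in the same run compound 2 gives 2480 nM, so that the step of a 1.1-fold higher number from compound 1 to compound 2 (0.03 log units; within the scatter). Compound 3 `O=C(NCCSc1ccc2c(/C=C/c3ccccn3)n[nH]c2c1)Nc1cccc(C(F)(F)F)c1` is built on a different core; the difference between the two cores is not broken down here. In this assay compound 3 gives 3000 nM, a number that sits within the scatter of both compound 1 and compound 2, so no ordering among the three is claimed.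

Compound 4 `CN1CCN(Cc2ccc(NC(=O)NCCSc3ccc4c(/C=C/c5ccccn5)n[nH]c4c3)cc2C(F)(F)F)CC1` has not yet been measured. It stands to compound 3 as compound 2 stands to compound 1: the change ((4-methylpiperazin-1-yl)methyl in place of hydrogen on an aromatic carbon). The two descriptions of the place of the change agree word for word, so this is the same change, appearing for the second time among these compounds.

Going by the values given here, the only guide to its size is the single earlier instance, the step of a 1.1-fold higher number from compound 1 to compound 2 (0.03 log units; within the scatter), which left the number essentially where it was. On that basis the step from compound 3 to compound 4 in this assay is expected to be a 1.1-fold higher number from compound 3 to compound 4 (0.03 log units; within the scatter), again within the scatter, with more uncertainty than usual since the earlier instance sits on a different core. Compound 4 is accordingly estimated at 3200 nM in this assay, with a likely range from 1600 nM to 6500 nM.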

Compound 4, concentration for 50% growth inhibition: 3100 nM
Beside the measured number, compound 4's estimate is 1.0-fold (0.01 log units) above it, and the stated range covers the measured number.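

In this assay, (4-methylpiperazin-1-yl)methyl in place of hydrogen on the aromatic carbon gives a 1.0-fold higher number from compound 3 to compound 4 (0.01 log units; within the scatter), so on this second core, as on the first, the change moves the number no further than the scatter. The two instances do not differ from each other: the same change on two cores in this assay, a 1.1-fold higher number (0.03 log units; within the scatter) from compound 1 to compound 2 and a 1.0-fold higher number (0.01 log units; within the scatter) from compound 3 to compound 4, 1.0-fold (0.02 log units) apart, within the scatter of two such steps This shows that, across these two cores and in this one assay, the change transfers as a step of no measurable size, but it does not show that the same would hold on any other core or in any other read-out, and two steps within the scatter establish no general rule for the series.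

The compounds shown leave open whether a different group in the same place, such as a morpholine, a dimethylamino group or a carboxylic acid carried on the same methyl carbon, would move the number, or whether only this particular amine leaves it unchanged. Also open, on these data alone, is whether a longer chain in the linker joining the sulfur to the trifluoromethyl-bearing ring would shift the number on either core, with or without the piperazine.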